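The compounds below may be only part of what the source reports. "The series", "measured", "known", "first", "only" and "open" are said of these compounds alone.

Measured compounds in a functional assay on A549 cells (Homo sapiens) for inhibition, read by MTT assay, with a stated time of 72 h, tested at 10 uM; a lower number here means less inhibition, a higher number more inhibition at the concentration tested (going by the name of the read-out):
Compound 1 `CCOC(=O)C1=C(Nc2ccccc2)S/C(=C\c2ccc(Br)c(O)c2)C1=O` gives 13.6%.
Compound 2 `CCOC(=O)C1=C(Nc2ccccc2)S/C(=C\c2cccc(C(=O)O)c2)C1=O` returns only a limit of the assay, < 10%.
Compound 3 `CCOC(=O)C1=C(Nc2cccc(C(F)(F)F)c2)S/C(=C\c2ccc[nH]2)C1=O` gives 22.8%.

Compound 2 thus stands at the limit of < 10% in this assay, at which 1 of the 3 values shown sits; its value is a limit, not a number. For the measured compounds named here, the one measured step that leads to it is a number at least 3.6 percentage points lower from compound 1 to compound 2 (that floor lies within the scatter). Compound 4 `CCOC(=O)C1=C(Nc2ccccc2)S/C(=C\c2cc3ccncc3[nH]2)C1=O` differs from compound 2 in one place: a group of 9 heavy atoms (7 carbon, 2 nitrogen; one five-membered aromatic ring with 1 hetero atom, one six-membered aromatic ring with 1 hetero atom) in place of a group of 9 heavy atoms (7 carbon, 2 oxygen; one six-membered aromatic ring of carbon only), on a double-bonded chain carbon bound to a double-bonded ring carbon. Going by the values given here, no measured step covers this exchange. Among the compounds with values here, compound 3 lies higher than compound 2, but it differs from compound 2 in two places, so it offers no single step to lean on. Within the data shown here, the only step that bears on compound 2, from compound 1 to compound 2, is small and downward and reaches the limit. Removing the 3-carboxyphenyl that brought compound 2 to the limit may lift the value, but the size is open. A moderate upward step is expected for compound 4, a number at least 8 percentage points higher from compound 2 to compound 4 (that floor lies within the scatter), with a fair chance that compound 4 again returns only a limit. Compound 4 is estimated at 18%, in the range 5% to 35%.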

Compound 4, a percentage reported as inhibition, at one concentration (the size of the read-out at that concentration, not a potency): 17.1%
Compound 4: the middle estimate sits 0.9 percentage points above what was measured; measured number inside the range.
By their numbers in this assay, from the lowest: compounds 1, 4 and 3 (each within the scatter of the next). At a limit, below all of these: compound 2.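

At the double-bonded chain carbon bound to a double-bonded ring carbon, replacing 3-carboxyphenyl with the group holding one five-membered and one six-membered aromatic ring, each with 1 hetero atom, gives in this assay a number at least 7.1 percentage points higher from compound 2 to compound 4 (that floor lies within the scatter). On these data alone, the value of compound 2, < 10%, is a limit and not a number, so the size of this step stays open. Replacing 4-bromo-3-hydroxyphenyl with the same group gives a number 3.5 percentage points higher from compound 1 to compound 4 (within the scatter), so this assay does not separate these two groups at this place.

The compounds shown leave open whether any group at this place can move the value beyond the scatter from compound 1 and compound 4. They also leave open how a non-aromatic group, such as an amine or a longer chain, would read at this place on the shared core.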